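The source may report more compounds than this note shows. Statements on the series, on what has been measured and on what is new or still open speak of the compounds shown alone.

Measured so far:
compound 1 `CNC(=O)CC1CCc2cc(OC)c(OC)cc21`: 30%
compound 2 `COc1cc2c(cc1OC)C(CC(=O)N(C)C)CC2`: 36%
compound 3 `CCN(CC)C(=O)CC1CCc2cc(OC)c(OC)cc21`: 40%

Three amides share one core and differ only at the amide nitrogen. In a functional assay on the whole organism (strain Wistar) for inhibition, with Rattus norvegicus as the target, read by paw edema, with stated times of 60 min and 2 h, at a dose of 100 mg/kg by the oral route (on this read-out lower numbers stand for less inhibition and higher numbers for more inhibition at the one dose given (going by the name of the read-out)), compound 3 gives 40%. The steps leading to it, a number 10 percentage points higher from compound 1 to compound 3 (within the scatter) and a number 4 percentage points higher from compound 2 to compound 3 (within the scatter), both lie within the scatter, as does a number 6 percentage points higher from compound 1 to compound 2 (within the scatter), so the three compounds cannot be told apart on these numbers.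

Compound 4 `CCCCNC(=O)CC1CCc2cc(OC)c(OC)cc21` is the next variation at the same place: butylamino in place of diethylamino on a carbonyl carbon. Every change made so far at this amide nitrogen has left the read-out unmoved beyond the scatter, and nothing measured singles out the butyl chain or the returning amide hydrogen. Compound 4 is therefore expected to show a number 5 percentage points lower from compound 3 to compound 4 (within the scatter), no step beyond the scatter. The estimated value of compound 4 is 35%, within the range 22% to 48%.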

Compound 4, a percentage reported as inhibition, in the whole organism at one dose (the size of the read-out at that dose, not a potency): 24%
Beside the measured number, compound 4's estimate is 11 percentage points above it, and the stated range covers the measured number.
By their numbers in this assay, from the lowest: compounds 4, 1, 2 and 3 (each within the scatter of the next, the first and the last beyond it).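

In this assay, this amide nitrogen now gives its first steps beyond the scatter, though modest ones: a number 16 percentage points lower from compound 3 to compound 4 (beyond the scatter) and a number 12 percentage points lower from compound 2 to compound 4 (beyond the scatter). Against the methylamino amide the butylamino amide stays close, at a number 6 percentage points lower from compound 1 to compound 4 (within the scatter), so the lengthened chain on a nitrogen that keeps its amide hydrogen cannot be read as a change. Nothing measured here explains the drop. Butylamino differs from diethylamino in both chain shape and the amide hydrogen, and these compounds do not separate the two. Dibutylamino, or a ring amine such as piperidine on the carbonyl carbon, remains an open question.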